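This account rests on a few compounds, and the source may have more. Where it says the series, first, only, none or still open, it means among the compounds named here.

The measured compounds:

compound 1, `Nc1nc(NCc2ccccc2)c2ncn(/C=C3/CC3(CO)CO)c2n1`: > 20000 nM
compound 2, `Nc1nc(N2CCCC2)c2ncn(/C=C3/CC3(CO)CO)c2n1`: "not determined" (no result reported)

In an ADME assay on MOLT-3 cells (Homo sapiens) for cytotoxicity, with a stated time of 7 days (a higher number here means that more compound is tolerated, a lower number that less compound is tolerated), compound 1 gives > 20000 nM, which is a limit of the assay and not a number. Compound 1 therefore sits at the limit of > 20000 nM in this assay, at which 1 of the 2 values shown sits. Compound 2 stands without a number of its own in this assay, since its result is "not determined" (no result reported), so nothing can be said of how it compares with compound 1.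

The step to compound 3, `CCCCCCCCSc1nc(N)nc2c1ncn2/C=C1/CC1(CO)CO`, changes the shared core in one place: octylsulfanyl in place of pyrrolidin-1-yl on an aromatic carbon. No measured step between two compounds with a result is available, so the size and direction of this step in this assay cannot be read off from anything shown. Given that the one result shown is a limit, compound 3 is expected to be tolerated at about the same level, with no step beyond the scatter and a fair chance that the assay again reports only a limit. Compound 3 is estimated at 20000 nM, in a range from 5000 nM to 60000 nM.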

Compound 3, half-maximal cytotoxic concentration: > 20000 nM
Compound 3: no number, only a limit; the forecaster's own chance of this, stated with the estimate: 55%; the middle value lies on the limit itself.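

In this assay compound 3 gives > 20000 nM, which is a limit of the assay and not a number. For the compounds shown here, compound 1 and compound 3 share this limit, so no step between them can be read: the limit of > 20000 nM in this assay, at which 2 of the 3 values shown sit. Still open, on these data alone, is how much of compound 1 or compound 3 is tolerated, and where compound 2 stands.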